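A few compounds are considered here, and "the series" means these few. Any claim that something is new, unique, unknown or untested is made for them only; others in the source may bear on it.

In a functional assay on SF-539 cells (Homo sapiens) for inhibition, read by sulforhodamine B assay, with a stated time of 48 h, tested at 10 uM (on this read-out higher numbers stand for a weaker effect at the one concentration tested and lower numbers for a stronger effect), compound 2 `COc1cc(Cl)cc(-c2nn(-c3cccc(NC(=O)Nc4ccc(Cl)c(C(F)(F)F)c4)c3)cc2-c2ccncc2)c1` gives -1.17%, which is the second highest of the three numbers at hand. Going by the values given here, its nearest neighbour is compound 3 `COc1cc(Cl)cc(-c2nn(-c3cccc(NC(=O)Nc4cc(C(F)(F)F)cc(C(F)(F)F)c4)c3)cc2-c2ccncc2)c1`, which gives -17.7%, and its furthest is compound 1 `O=C(Nc1cccc(-n2cc(-c3ccncc3)c(-c3cc(O)cc(Cl)c3)n2)c1)Nc1ccc(Cl)c(C(F)(F)F)c1`, which gives 32.6%; the single step from compound 1 to compound 2 is a change of a number 33.8 percentage points lower from compound 1 to compound 2 (beyond the scatter).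

Compound 4 `COc1cc(Cl)cc(-c2nn(-c3cccc(NC(=O)c4cccc(C(F)(F)F)c4)c3)cc2-c2ccncc2)c1` differs from compound 2 by 3-(trifluoromethyl)phenyl in place of (4-chloro-3-(trifluoromethyl)phenyl)amino on a carbonyl carbon. Among the compounds with values here, no measured step touches this kind of change, so the only guide is that the three known numbers sit over a modest span. I therefore expect a step of a number 13.2 percentage points higher from compound 2 to compound 4 (beyond the scatter), a shift of uncertain direction, and estimate for compound 4 a value of 12%, between -12% and 38%.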

Compound 4, a percentage reported as activity, at one concentration (the size of the read-out at that concentration, not a potency): 64.2%
The estimate for compound 4 lay 52.2 percentage points below the measured number; measured number outside the range, above it.
By their numbers in this assay, from the lowest: compound 3; then compound 2; then compound 1; then compound 4.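

In this assay the group on this carbonyl carbon matters greatly: a number 65.4 percentage points higher from compound 2 to compound 4 (beyond the scatter), which means a much weaker effect at the one concentration tested. The change removes the amino nitrogen, with its hydrogen-bond donor, and the ring chlorine together, so these compounds cannot show which loss counts. No evidence at hand explains the step. Still open, from the compounds shown here alone, is how (3-(trifluoromethyl)phenyl)amino would read here, since it keeps the amino nitrogen but lacks the chlorine. Also open, going by these compounds, is whether a methylamino link in place of the amino nitrogen would hold the effect of compound 2.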